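Cytotoxicity notes on the halogen swap from compound 3 to compound 4

This account rests on a few compounds, and the source may have more. Where it says the series, first, only, none or still open, it means among the compounds named here.

compound 1 `CNC(=O)c1c(NO)cc(-c2ccc(Cl)cc2)oc1=O`: > 20000 nM
compound 2 `COC(=O)CNC(=O)c1c(NO)cc(-c2ccc(Cl)cc2)oc1=O`: > 20000 nM
compound 3 `O=C(NCc1ccccc1)c1c(NO)cc(-c2ccc(F)cc2)oc1=O`: > 20000 nM

Among the compounds with values here, in an ADME assay on Huh-7 cells (Homo sapiens) for cytotoxicity, read by a luciferase reporter and WST assay, with a stated time of 3 days (a lower number here means that less compound is tolerated, a higher number that more compound is tolerated), no compound has yet given a number. Compound 1 gives only a limit of the assay, > 20000 nM. Compound 2 also stands at a limit, > 20000 nM. Compound 3 likewise reports a limit, > 20000 nM. Within the data shown here, the one single-point step in the set, a step that the two limits leave unreadable from compound 1 to compound 2, is unreadable for that reason, its change being methoxycarbonyl in place of hydrogen on a saturated chain carbon bound to an amide-type nitrogen. The common thread is the limit of > 20000 nM in this assay, at which 3 of the 3 values shown sit.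

Compound 4 `O=C(NCc1ccccc1)c1c(NO)cc(-c2ccc(Cl)cc2)oc1=O` differs from compound 3 by chloro in place of fluoro on an aromatic carbon. Among the measured compounds shown here, no measured step tests this change, but compound 1 and compound 2 already carry the 4-chlorophenyl and both sit at the limit. Compound 4 is therefore expected to show no shift beyond the scatter, with the step that the limit leaves unreadable from compound 3 to compound 4 estimated as essentially flat. The estimate for compound 4 is 30000 nM, range 15000 nM to 100000 nM, most likely reported again as a limit.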

Compound 4, half-maximal cytotoxic concentration: > 20000 nM
Compound 4 gave a limit, no number (the forecaster's own chance of this, stated with the estimate: 85%); the middle value does not contradict the limit.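

In this assay, the steps joining compound 4 to compound 1, compound 2 and compound 3 cannot be read, because all four compounds give only a limit: the limit of > 20000 nM in this assay, at which 4 of the 4 values shown sit.

The compounds shown leave open whether any change on the shared core gives a measurable half-maximal cytotoxic concentration.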